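The compounds below may be only part of what the source reports. "The series", "measured", "known", "first", "only" and "open" are said of these compounds alone.

In an in vivo ADME assay on the whole organism (strain Sprague-Dawley) for metabolic stability, with Rattus norvegicus as the target (a lower number here means that the compound disappears faster, a higher number that the compound lasts longer), compound 3 `CCCCCOC(=O)N1CCN(C(=O)[C@H](CCC(=O)O)NC(=O)c2cc(N3CCC(C(=O)N(CC)CC)CC3)nc(-c3ccccc3)n2)CC1` gives 0.00667 h, the second highest of three numbers. Its nearest neighbour is compound 2 `CCCCCOC(=O)N1CCN(C(=O)[C@H](CCC(=O)O)NC(=O)c2nc(-c3ccccc3)cc(N3CCC(COC)CC3)n2)CC1`, which in this assay gives 0.005 h, within the scatter of compound 3. Furthest away is compound 1 `CCCCCOC(=O)N1CCN(C(=O)[C@H](CCC(=O)O)NC(=O)c2cc(N3CCC(COC)CC3)nc(-c3ccccc3)n2)CC1`, which in this assay gives 0.015 h; the step of a 2.2-fold lower number from compound 1 to compound 3 (0.35 log units; beyond the scatter) is the one measured change on this saturated ring carbon. Compound 4 `CCCCCOC(=O)N1CCN(C(=O)[C@H](CCC(=O)O)NC(=O)c2cc(N3CCC(CNC)CC3)nc(-c3ccccc3)n2)CC1` differs from compound 3 in one place: (methylamino)methyl in place of diethylcarbamoyl on a saturated ring carbon. For the measured compounds named here, only that earlier step bears on this change, and it was modest, so a shift of about that size in this assay is expected, with the direction uncertain. The estimate for compound 4 in this assay is 0.01 h, between 0.004 h and 0.025 h, an expected step of a 1.5-fold higher number from compound 3 to compound 4 (0.18 log units; within the scatter).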

Compound 4, half-life: 0.0117 h
The estimate for compound 4 lay 1.2-fold (0.07 log units) below the measured number; low and high end bracket the measured number.
By their numbers in this assay, from the lowest: compounds 2, 3, 4 and 1 (each within the scatter of the next, the first and the last beyond it).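

In this assay, (methylamino)methyl in place of diethylcarbamoyl on this saturated ring carbon gives a 1.8-fold higher number from compound 3 to compound 4 (0.24 log units; within the scatter). Methylamino in place of methoxy on the saturated chain carbon gives a 1.3-fold lower number from compound 1 to compound 4 (0.11 log units; within the scatter). Compound 4 therefore lies within the scatter of both compound 1 and compound 3, although those two lie beyond the scatter of each other, so neither new step shows a clear change in half-life. On these data alone, whether a carboxylic acid or a longer chain at this ring carbon would give a step beyond the scatter remains open. No measurement here explains these steps.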